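Cytotoxicity notes on a fused two-ring amine series

The source may hold more compounds than are shown below. What is called first, only, known or untested is meant among the compounds shown, and "the series" means these compounds.

Measured compounds:
compound 1 `Fc1ccc(-c2ccc3c(NCCCNCc4ccco4)ccnc3c2)cc1` 7760 nM
compound 2 `COc1cccc(CNCCCNc2ccnc3cc(-c4ccc(C(F)(F)F)cc4)ccc23)c1O` 2210 nM
compound 3 `FC(F)(F)c1ccc(-c2ccc3c(NCCCNCc4ccco4)ccnc3c2)cc1` 3470 nM

Three compounds have been run in an ADME assay on HepG2 cells (Homo sapiens) for cytotoxicity, read by luminescence, CellTiter-Glo and ATP content, with a stated time of 72 h; on this read-out higher numbers stand for an effect only at larger amounts of compound and lower numbers for an effect already at smaller amounts. Compound 2 gives the lowest number of the three; against compound 3 it lies within the scatter, against compound 1 it lies beyond it.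

Compound 4 `COc1cccc(CNCCCNc2ccnc3cc(CC4CCCCC4)ccc23)c1O` is not yet measured. It differs from compound 2 in one place: cyclohexylmethyl in place of 4-(trifluoromethyl)phenyl on an aromatic carbon

Two measured steps exist. The one at the same position, a 2.2-fold lower number from compound 1 to compound 3 (0.35 log units; beyond the scatter), shows that exchanging a substituent on the pendant ring moves this assay modestly. The other, a 1.6-fold higher number from compound 2 to compound 3 (0.20 log units; within the scatter), concerns the far end of the chain and stays within the scatter. Neither step replaces the whole aromatic ring by a saturated group, so the change to compound 4 is not covered by anything measured. The expectation therefore rests on the narrow spread of the three measured numbers: compound 4 is expected to stay close to compound 2, with a step of a 1.6-fold higher number from compound 2 to compound 4 (0.20 log units; within the scatter) that may not exceed the scatter. The estimate for compound 4 in this assay is 3500 nM, in a range from 1300 nM to 9500 nM.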

Compound 4, half-maximal effective concentration: 970 nM
Compound 4: middle estimate off by 3.6-fold (0.56 log units), on the high side; measured number below the stated range.
By their numbers in this assay, from the lowest: compound 4; then compounds 2 and 3 (each within the scatter of the next); then compound 1.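

In this assay, replacing 4-(trifluoromethyl)phenyl with cyclohexylmethyl on the aromatic carbon gives a 2.3-fold lower number from compound 2 to compound 4 (0.36 log units; beyond the scatter) and shows that this position does not need a pendant aromatic ring for the number to stay low, at least with the 2-hydroxy-3-methoxyphenyl end on the chain. Going by these compounds alone, the only earlier step at this position, a 2.2-fold lower number from compound 1 to compound 3 (0.35 log units; beyond the scatter), exchanged a substituent on a retained aromatic ring, whereas this one replaces the ring itself, and both are printed as modest and beyond the scatter, with a lower number on the second compound. Nothing shown gives a reason for the shift, so this pair records only the direction and size of one change.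

The compounds shown leave open whether the saturated ring or the methylene link accounts for the step, which a benzyl group or a directly attached cyclohexyl on the same aromatic carbon would separate. Also open, as far as these compounds go, are whether the step carries over to the furan-2-yl end of the chain and how an amine or a carboxylic acid on the cyclohexyl ring would move the number.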